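Exchanging the aryl group of compound 1: an aryl swap

The source may report more compounds than this note shows. Statements on the series, on what has been measured and on what is new or still open speak of the compounds shown alone.

Compound 1, `Cc1cc(C)cc(-n2cc(COC(=O)c3cc4ccccc4[nH]3)nn2)c1`, gives 30200 nM in a functional assay on HeLa cells (Homo sapiens) for cytotoxicity, read by MTT assay, with a stated time of 48 h; a higher number here means a weaker inhibitor, a lower number a stronger inhibitor.
Compound 2, `O=C(OCc1cn(-c2cccc(C(F)(F)F)c2)nn1)c1cc2ccccc2n1Cc1cn(-c2cccc(C(F)(F)F)c2)nn1`, gives 9890 nM in this assay.
Compound 3, `O=C(OCc1cn(-c2cccc(C(F)(F)F)c2)nn1)c1cc2ccccc2[nH]1`, gives 11700 nM in this assay.

Of the three numbers, compound 1 has the highest, and its distance from both compound 3 and compound 2 lies beyond the scatter, so compound 1 is the weakest of the measured set. Compound 4, `COc1ccc(-n2cc(COC(=O)c3cc4ccccc4[nH]3)nn2)cc1`, differs from compound 1 in one place: 4-methoxyphenyl in place of 3,5-dimethylphenyl on an aromatic nitrogen. Among the compounds with values here, no pair of measured compounds shows this change; the other measured compounds differ from compound 1 elsewhere, so the size of the step has no direct precedent. A modest step toward a lower number, close to the edge of the scatter, is expected, a 1.5-fold lower number from compound 1 to compound 4 (0.18 log units; within the scatter). Compound 4 is thus estimated at 20000 nM, with a range from 7000 nM to 60000 nM.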

Compound 4, half-maximal inhibitory concentration: 16100 nM
Compound 4: middle estimate off by 1.2-fold (0.09 log units), on the high side; the range from low to high includes it.
By their numbers in this assay, from the lowest: compounds 2, 3, 4 and 1 (each within the scatter of the next, the first and the last beyond it).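

In this assay, within the data shown here, the exchange of 3,5-dimethylphenyl for 4-methoxyphenyl on the aromatic nitrogen gives a 1.9-fold lower number from compound 1 to compound 4 (0.27 log units; within the scatter) and provides the first direct step at this position. The entering group adds a hydrogen-bond acceptor at an equal heavy-atom count, yet this single exchange does not separate compound 4 from compound 1. Nothing measured here bears on the closeness of these two values. On these data alone, whether an aryl group carrying an amine or a carboxylic acid would take the number beyond the scatter stays open. So does the outcome with a longer alkyl chain in place of the aryl group.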